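The source may hold more compounds than are shown below. What is called first, only, known or untested is meant among the compounds shown, and "the series" means these compounds.

Measured compounds:
compound 1, `Cc1nnc(SCc2ccccc2Cl)n1N1C(=O)c2ccccc2C1=O`, giving > 200000 nM in a functional assay on PC-3M cells (Homo sapiens) for cytotoxicity, read by MTT assay, with a stated time of 48 h; a higher number here means a weaker inhibitor, a lower number a stronger inhibitor
compound 2, `C#CCSc1nnc(CCC)n1N1C(=O)c2ccccc2C1=O`, giving > 200000 nM in this assay

The value for compound 1 in this assay is a limit of the assay, not a number. The value for compound 2 in this assay is likewise a limit and not a number. Where compound 2 stands is therefore only this: it sits at the limit shown by the limit of > 200000 nM in this assay, at which 2 of the 2 values shown sit, and the two values recorded so far show no ordering between compound 1 and compound 2.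

Compound 3, `CCCc1nnc(SCc2ccccc2Cl)n1N1C(=O)c2ccccc2C1=O`, differs from compound 2 by 2-chlorophenyl in place of ethynyl on a saturated chain carbon bound to a sulfur; read one bond further out, propargyl becomes 2-chlorobenzyl and propargylsulfanyl becomes (2-chlorobenzyl)sulfanyl. Compound 3 thus carries the (2-chlorobenzyl)sulfanyl group found in compound 1 on the propyl-bearing core of compound 2. Within the data shown here, no step between measured compounds exists in this assay to size this change. Given that both measured compounds sit at the limit (the limit of > 200000 nM in this assay, at which 2 of the 2 values shown sit), the step that the limit leaves unreadable from compound 2 to compound 3 is expected to be none beyond the scatter. Compound 3 is accordingly expected near 250000 nM in this assay, within 80000 nM to 800000 nM, and most likely reported again only as a limit.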

Compound 3, half-maximal inhibitory concentration: > 200000 nM
Compound 3: no number, only a limit; the forecaster's own chance of this, stated with the estimate: 80%; the middle value does not contradict the limit.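

In this assay compound 3 gives > 200000 nM, which is a limit of the assay and not a number. No step from compound 1 or compound 2 to compound 3 can be read, as all values rest on one limit: the limit of > 200000 nM in this assay, at which 3 of the 3 values shown sit.

The compounds shown leave open which change on the shared core, if any, would give a measurable value in this assay.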